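Replacing a Chlorophenyl Hydrazide Arm with a Fluorobenzoyl Group

The source may hold more compounds than are shown below. What is called first, only, known or untested is meant among the compounds shown, and "the series" means these compounds.

Compound 1, `O=C(NNc1ccccc1F)c1ccc(NS(=O)(=O)c2cnc(O)nc2O)cc1`, in a functional assay on MDA-MB-231 cells (Homo sapiens) for antiproliferative activity, read by MTT assay, with a stated time of 24 h (a higher number here means a weaker inhibitor, a lower number a stronger inhibitor), compound 1 gives > 20000 nM, which is a limit of the assay rather than a number. Compound 2, `O=C(NNc1ccccc1Cl)c1ccccc1NS(=O)(=O)c1cnc(O)nc1O`, in this assay compound 2 gives 18900 nM. Compound 3, `O=C(NNC(=O)c1cccc(NS(=O)(=O)c2cnc(O)nc2O)c1)c1ccc(F)cc1`, in this assay compound 3 gives > 20000 nM, again a limit of the assay.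

Among the three measured compounds, compound 2 is the only one with an actual number in this assay; the other two sit at the limit of > 20000 nM in this assay, at which 2 of the 3 values shown sit. Even so, the number for compound 2 is not far from that limit, so all three compounds show weak activity in this assay.

Compound 4, `O=C(NNC(=O)c1ccccc1NS(=O)(=O)c1cnc(O)nc1O)c1ccc(F)cc1`, has not yet been measured. It differs from compound 2 in one place: (4-fluorophenyl)carbonyl in place of 2-chlorophenyl on an amine nitrogen. For the measured compounds named here, compound 3 already carries this same entering group and sits at the limit of the assay, while compound 2 with the leaving group gives the one number seen. Going by the values given here, with no directly comparable pair among the measured compounds, the step from compound 2 to compound 4 is expected to be small, at most a modest loss of potency, so compound 4 is expected to give 22000 nM in this assay, within a range from 8000 nM to 60000 nM, with the step of a 1.2-fold higher number from compound 2 to compound 4 (0.07 log units; within the scatter) expected to stay close to the scatter, and compound 4 may even be expected to end at a limit of the assay.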

Compound 4, half-maximal inhibitory concentration: > 20000 nM
Compound 4: no number, only a limit; the forecaster's own chance of this, stated with the estimate: 60%; the middle value lies beyond the limit too.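

For the compounds shown here, compound 2 and compound 4 give the first direct comparison at this place, an amine nitrogen whose other neighbour is an amide-type nitrogen. Putting (4-fluorophenyl)carbonyl there in place of 2-chlorophenyl adds a carbonyl and one hydrogen-bond acceptor, and the result is an at least 1.0-fold higher number from compound 2 to compound 4 (0.02 log units; that floor lies within the scatter) in this assay, so this change gives no sign of a stronger inhibitor. The true size of the step cannot be read, and this position cannot be ranked any more finely, because compound 4 gives only a limit of the assay, not a number: the limit of > 20000 nM in this assay, at which 3 of the 4 values shown sit.

The change swaps more than one feature at once, so (2-chlorophenyl)carbonyl at this place would be needed to separate the effect of adding the carbonyl from that of exchanging the halogen-bearing ring. The compounds shown also leave open whether a much smaller or differently built group on this nitrogen, such as a methyl, a longer alkyl chain or an arm ending in a carboxylic acid or an amine, could bring a clear number well inside the range of the assay.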